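This account rests on a few compounds, and the source may have more. Where it says the series, first, only, none or still open, it means among the compounds named here.

Working notes on the series. Three compounds have been run in a functional assay on CHO cells for antagonist activity at prostaglandin E2 receptor EP4 subtype (Homo sapiens), read by calcium flux, with a stated time of 15 min; on this read-out higher numbers stand for weaker inhibition and lower numbers for stronger inhibition. Compound 1 `C[C@H](NC(=O)c1nnn(Cc2ccc(F)cc2)c1C(F)(F)F)c1ccc(C(=O)O)cc1` returns in this assay > 10000 nM, which is a limit of the assay and not a number. Compound 2 `C[C@H](NC(=O)c1nnn(Cc2cccc(C(F)(F)F)c2)c1C(F)(F)F)c1ccc(C(=O)O)cc1` returns in this assay > 10000 nM, again a limit. Among the compounds with values here, the one step between compounds differing in a single place, a step that the two limits leave unreadable from compound 1 to compound 2, cannot be sized because both ends sit at the limit of > 10000 nM in this assay, at which 2 of the 3 values shown sit. Within the data shown here, compound 3 `C[C@H](NC(=O)c1c(-c2ccccc2)nnn1Cc1ccc(F)c(F)c1)c1ccc(C(=O)O)cc1` gives in this assay 148 nM, the only number among the three values shown.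

Compound 4 `C[C@H](NC(=O)c1c(-c2ccccc2)nnn1CC1CCCCC1)c1ccc(C(=O)O)cc1` is not yet measured in this assay. It differs from compound 3 in one place: cyclohexyl in place of 3,4-difluorophenyl on a saturated chain carbon bound to an aromatic nitrogen. Among the measured compounds shown here, no measured step covers this change, and the single recorded step is itself unreadable, so there is nothing to scale the move from. The expectation rests on compound 3 alone and on the size of the group exchanged. For compound 4 the expected step is a 2.4-fold higher number from compound 3 to compound 4 (0.37 log units; beyond the scatter), a small loss that the scatter could easily swallow. Compound 4 is thus estimated at 350 nM, with a range from 90 nM to 2000 nM, in this assay.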

Compound 4, half-maximal inhibitory concentration: > 10000 nM
Compound 4 ended at the assay's limit (the forecaster's own chance of this, stated with the estimate: 10%); middle value at least 28-fold (1.45 log units) from the limit.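

Within the data shown here, exchanging 3,4-difluorophenyl for cyclohexyl on a saturated chain carbon bound to an aromatic nitrogen gives the first readable step at this position in this assay: an at least 67-fold higher number from compound 3 to compound 4 (1.82 log units; beyond the scatter). The value of compound 4, > 10000 nM, is a limit of the assay and not a number. Among these compounds, with compound 3 as the one measured number, the pair shows that, with the phenyl group kept on the shared core, the result at this place differs sharply between one six-membered aromatic ring of carbon only and one six-membered non-aromatic ring of carbon only, while the earlier step at this place cannot be read and most of the series remains unresolved: the limit of > 10000 nM in this assay, at which 3 of the 4 values shown sit.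

The change removes the aromatic ring and both fluorines in a single move, and the compounds shown do not separate these two differences; an unsubstituted benzyl group at this place would be needed to part them. Compound 1 and compound 2 each differ from compound 3 in more than one place, which leaves open how a trifluoromethyl group compares with the phenyl group on the shared core.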